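The compounds below may be only part of what the source reports. "The series", "measured", "known", "first", "only" and "open" are said of these compounds alone.

Measured so far in a functional assay on A549 cells (Homo sapiens) for inhibition, read by MTT assay, with a stated time of 72 h; a lower number here means a stronger inhibitor, a higher number a weaker inhibitor:
- compound 1, `CC(O)c1cn(Cc2cc(=O)oc3cc(O)ccc23)nn1`, gives > 100000 nM, a limit of the assay
- compound 2, `O=c1cc(Cn2cc(CCCCO)nn2)c2ccc(O)cc2o1`, gives > 100000 nM, also a limit of the assay

Compound 2 therefore stands only at a limit in this assay, with no number to place it against. For the measured compounds named here, the one step between measured compounds, a step that the two limits leave unreadable from compound 1 to compound 2, cannot be read, since both ends sit at the same limit; the limit of > 100000 nM in this assay, at which 2 of the 2 values shown sit, sums up the position.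

Compound 3, `O=c1cc(Cn2cc(CCc3ccccc3)nn2)c2ccc(O)cc2o1`, is not yet measured in this assay. It differs from compound 2 by phenyl in place of 2-hydroxyethyl on a saturated chain carbon, two bonds along the chain from an aromatic carbon. Going by the values given here, no measured step bears on this change: the only step known, from a hydroxyalkyl chain to another, is unreadable, and nothing measured carries a phenyl at this place. The expectation for compound 3 thus rests on compound 2 alone.

The working expectation is that compound 3 remains at or close to the limit of compound 2, with the step of an at least 1.2-fold lower number from compound 2 to compound 3 (0.09 log units; that floor lies within the scatter) estimated as small and uncertain. The estimate for compound 3 in this assay is 80000 nM, with a range from 20000 nM to 150000 nM.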

Compound 3, half-maximal inhibitory concentration: 24800 nM
Beside the measured number, compound 3's estimate is 3.2-fold (0.51 log units) above it, within the range that was stated.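

In this assay, for the compounds shown here, this position now has a readable direction and a lower bound on size: phenyl in place of 2-hydroxyethyl on a saturated chain carbon, two bonds along the chain from an aromatic carbon, gives an at least 4.0-fold lower number from compound 2 to compound 3 (0.60 log units; beyond the scatter) and thus the first step that can be read. Phenethyl in place of 1-hydroxyethyl on an aromatic carbon gives an at least 4.0-fold lower number from compound 1 to compound 3 (0.60 log units; beyond the scatter) in the same direction, so both hydroxyalkyl chains shown sit on the weaker side of the phenethyl group. The change removes the hydroxyl and brings in the six-membered aromatic ring in one move, and neither step can separate the two.

As far as these compounds go, whether the ring or the loss of the hydroxyl carries the step stays open, and a plain butyl chain, or a phenethyl group bearing an amine or a carboxylic acid, would bear on that question. The true size of both steps also stays open, with compound 1 and compound 2 held at a limit and not at a number: the limit of > 100000 nM in this assay, at which 2 of the 3 values shown sit.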